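This account rests on a few compounds, and the source may have more. Where it says the series, first, only, none or still open, it means among the compounds named here.

Compound 1 `Fc1ccccc1NC(=S)N/N=C/c1ccc2ccccc2n1` carries a fluoro group on its phenyl ring. In a functional assay on HeLa cells (Homo sapiens) for antiproliferative activity, read by sulforhodamine B assay, with a stated time of 72 h (a lower number here means a stronger inhibitor, a higher number a weaker inhibitor), compound 1 reaches only > 100000 nM, which is a limit of the assay, the point where (the limit of > 100000 nM in this assay, at which 1 of the 3 values shown sits). Two further compounds share a different core. Compound 2 `NC(=S)N/N=C/c1nc2ccccc2s1` gives 5350 nM in this assay. Compound 3 `CN(C)C(=S)N/N=C/c1nc2ccccc2s1` gives 2100 nM, so that a 2.5-fold lower number from compound 2 to compound 3 (0.41 log units; beyond the scatter). Compound 4 `S=C(N/N=C/c1ccc2ccccc2n1)Nc1ccccc1` differs from compound 1 in one place: hydrogen in place of fluoro on an aromatic carbon. Among the measured compounds shown here, this change sits at a different part of the molecule from the one seen between compound 2 and compound 3, so no measured step bears directly on it. Compound 1 already sits at the limit. The loss of the fluoro alone is a small change, so the expected step that the limit leaves unreadable from compound 1 to compound 4 is none beyond the scatter, and the number for compound 4 will most likely again be reported only as a limit. Compound 4 is therefore estimated at 120000 nM, within a range from 40000 nM to 400000 nM.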

Compound 4, half-maximal inhibitory concentration: 27400 nM
For compound 4 the middle estimate is 4.4-fold (0.64 log units) above the measured one; the measured number lies below the stated range.
By their numbers in this assay, from the lowest: compound 3; then compound 2; then compound 4. At a limit, above all of these: compound 1.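

Replacing the fluoro group with hydrogen, the change from 2-fluorophenyl to phenyl, gives in this assay an at least 3.6-fold lower number from compound 1 to compound 4 (0.56 log units; beyond the scatter), so this one substitution on the aromatic ring is enough to move the number beyond the scatter. For compound 1, > 100000 nM is a limit of the assay and not a number. The full size of the step therefore cannot be read, because only one end of it is a measured number: the limit of > 100000 nM in this assay, at which 1 of the 4 values shown sits.

On these data alone, it remains open whether a chloro, methoxy or amino group at this same place would give a number closer to that of compound 4 or to the limit of compound 1. As far as these compounds go, it also remains open how a fluoro group elsewhere on the phenyl ring would compare, and the data give no cause for the step.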